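The source may hold more compounds than are shown below. What is called first, only, known or untested is meant among the compounds shown, and "the series" means these compounds.

Compound 1 `COc1ccc2nc(C)cc(OCC(=O)Nc3cc(C)cc(C)c3)c2c1` — 18.9 mL.min-1.g-1
Compound 2 `COc1ccc2nc(C)cc(OC(C)(C)C(=O)Nc3cc(C)cc(C)c3)c2c1` — 27.3 mL.min-1.g-1
Compound 3 `COc1ccc2nc(C)cc(OCC(=O)Nc3cccc(C)c3)c2c1` — 18.1 mL.min-1.g-1

In an ADME assay on microsomes from liver (Mus musculus) for metabolic stability, read by LC-MS, using NADPH, with a stated time of 30 min, tested at 0.5 uM (a lower number here means slower removal, a higher number faster removal of the compound), compound 3 gives 18.1 mL.min-1.g-1, a number that is not separated beyond the usual scatter from either compound 1 or compound 2. Compound 4 `COc1ccc2nc(C)cc(OCC(=O)Nc3cc(C)ccc3C)c2c1` differs from compound 3 by methyl in place of hydrogen on an aromatic carbon. Among the measured compounds shown here, the only measured step that bears on a single aromatic methyl is a 1.0-fold lower number from compound 1 to compound 3 (0.02 log units; within the scatter), which stayed within the scatter. On that basis the step of a 1.1-fold higher number from compound 3 to compound 4 (0.04 log units; within the scatter) is expected to stay within the scatter as well, with no clear direction. Compound 4 is therefore estimated at 20 mL.min-1.g-1, with a range from 11 mL.min-1.g-1 to 36 mL.min-1.g-1 in this assay.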

Compound 4, intrinsic clearance in microsomes: 50.2 mL.min-1.g-1
Estimate against measurement, compound 4: 2.5-fold (0.40 log units) below; the whole stated range lies below it.
By their numbers in this assay, from the lowest: compounds 3, 1, 2 and 4 (each within the scatter of the next, the first and the last beyond it).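

In this assay, methyl on the aromatic carbon ortho to a large group and para to a methyl group gives a 2.8-fold higher number from compound 3 to compound 4 (0.44 log units; beyond the scatter), whereas the earlier step on an aromatic methyl, a 1.0-fold lower number from compound 1 to compound 3 (0.02 log units; within the scatter), stayed within the scatter. With two methyl groups on the ring in both compounds, 2,5-dimethylphenyl in place of 3,5-dimethylphenyl gives a 2.7-fold higher number from compound 1 to compound 4 (0.42 log units; beyond the scatter), so where the methyl stands counts here, not only how many there are. No measurement at hand accounts for this.

Open, as far as these compounds go, is whether fluorine, methoxy or an amine on that same carbon would give a similar step. Also open, from the compounds shown here alone, is whether the methyl would do the same on the chain of compound 2.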